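Closing the Amine into a Ring on a Cinnamic Acid Chain

The compounds below may be only part of what the source reports. "The series", "measured", "known", "first", "only" and "open" are said of these compounds alone.

Measured compounds:
compound 1, `COc1cc(/C=C/C(=O)Nc2ccccc2)ccc1OCCCCCCN1CCCCC1`: 1.77
compound 2, `CCN(CC)CCCCCCOc1ccc(/C=C/C(=O)O)cc1OC`: 1.29

Of the compounds shown here, two have been measured in a physicochemical assay for lipophilicity, using the shake flask method, measured as octanol-water partition, at pH 7.4; on this read-out lower numbers stand for lower lipophilicity and higher numbers for higher lipophilicity. Compound 1 gives 1.77, and compound 2 gives 1.29. Compound 2 therefore stands as the lower of the two numbers, with compound 1 sitting higher by a gap that is beyond the usual scatter of this kind of measurement. Compound 1 and compound 2 differ in more than one place, so their gap cannot be tied to a single structural change.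

Compound 3, `COc1cc(/C=C/C(=O)O)ccc1OCCCCCCN1CCCCC1`, has not yet been measured. It differs from compound 2 in one place: piperidin-1-yl in place of diethylamino on a saturated chain carbon, six bonds along the chain from an oxygen on an aromatic ring. The entering group carries one more heavy atom than the leaving group and closes the two ethyl arms into a six-membered non-aromatic ring; the acid end and the rest of the chain stay as they are.

For the measured compounds named here, no measured pair shows this exact change, so its effect rests on expectation alone. The step from compound 2 to compound 3 in this assay is expected to be small and upward, about a number 0.26 log units higher from compound 2 to compound 3 (within the scatter), close to the edge of the scatter. Compound 3 is accordingly expected to give about 1.55, within a range from 1.15 to 1.95.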

Compound 3, partition coefficient: 1.32
Compound 3: the middle estimate sits 0.23 log units above what was measured; measured number inside the range.
By their numbers in this assay, from the lowest: compounds 2 and 3 (each within the scatter of the next); then compound 1.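

In this assay, closing the two ethyl arms of diethylamino into piperidin-1-yl on a saturated chain carbon, six bonds along the chain from an oxygen on an aromatic ring, now has a direct reading: the step is a number 0.03 log units higher from compound 2 to compound 3 (within the scatter) and so gives no sign of a real difference, even though the entering group carries one more heavy atom and a six-membered non-aromatic ring. The new compound also supplies a second single-place comparison, hydroxy in place of anilino on a carbonyl carbon, and this step is a number 0.45 log units lower from compound 1 to compound 3 (beyond the scatter), so in this pair the swap on the carbonyl carbon shows up clearly where the swap of the amine groups does not. Nothing available here accounts for either step.

The compounds shown leave open whether another ring amine, such as pyrrolidine or morpholine, would read like piperidin-1-yl on this chain, or whether a longer chain would change the picture. They also leave open whether the exchange of diethylamino for piperidin-1-yl would give an equally small step with anilino on the carbonyl carbon in place of hydroxy.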